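The compounds below may be only part of what the source reports. "The series", "measured", "known", "first", "only" and "open" are said of these compounds alone.

Series notes. Compound 1 `COc1nc(C2=NOCC(c3ccc(C)cc3)N2)ccc1-n1cnc(C)c1` gives 135 mL/min/kg in an ADME assay on cells (Hepatocyte, Homo sapiens) for pharmacokinetics; a higher number here means faster removal of the compound, a lower number slower removal. Compound 2 `COc1nc(C2=NOCC(c3ccc(C(F)(F)F)cc3)N2)ccc1-n1cnc(C)c1` gives 12 mL/min/kg in this assay, and compound 3 `COc1nc(C2=NOCC(c3ccc(C(C)(C)C)cc3)N2)ccc1-n1cnc(C)c1` gives 320 mL/min/kg. Compound 3 has the highest number of the three: a 2.4-fold higher number from compound 1 to compound 3 (0.37 log units; beyond the scatter), and a 27-fold higher number from compound 2 to compound 3 (1.43 log units; beyond the scatter). Compound 4 `COc1nc(C2=NOCC(c3ccc(Cl)c(C4CC4)c3)N2)ccc1-n1cnc(C)c1` differs from compound 3 by 4-chloro-3-cyclopropylphenyl in place of 4-(tert-butyl)phenyl on a saturated ring carbon. Among the measured compounds shown here, the steps that bear on this change all alter the group on the same aromatic carbon: an 11-fold lower number from compound 1 to compound 2 (1.05 log units; beyond the scatter) was large, a 27-fold higher number from compound 2 to compound 3 (1.43 log units; beyond the scatter) was large, and a 2.4-fold higher number from compound 1 to compound 3 (0.37 log units; beyond the scatter) was modest, so this position moves the read-out strongly in this assay. A lower number is expected for compound 4 in this assay, by a sizeable step, a 3.2-fold lower number from compound 3 to compound 4 (0.51 log units; beyond the scatter). For compound 4 the estimate is 100 mL/min/kg, with a range from 30 mL/min/kg to 320 mL/min/kg.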

Compound 4, clearance: 274 mL/min/kg
Estimate against measurement, compound 4: 2.7-fold (0.44 log units) below; the range from low to high includes it.
By their numbers in this assay, from the lowest: compound 2; then compound 1; then compounds 4 and 3 (each within the scatter of the next).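

With a 1.2-fold lower number from compound 3 to compound 4 (0.07 log units; within the scatter), 4-chloro-3-cyclopropylphenyl cannot be told apart from 4-(tert-butyl)phenyl in this assay, so two different groups with the same heavy-atom count now share the top of the series. The other steps keep that group well clear of the rest: a 23-fold higher number from compound 2 to compound 4 (1.36 log units; beyond the scatter), and a 2.0-fold higher number from compound 1 to compound 4 (0.31 log units; beyond the scatter). No supporting data explain these numbers.

Open, going by these compounds, is how chlorine and cyclopropyl each contribute on their own. Also open, on these data alone, is whether an amine or a carboxylic acid on this aromatic ring would bring the number near that of compound 2.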